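From 4-fluorophenyl to 4-chlorophenyl

The source may hold more compounds than are shown below. What is called first, only, known or untested is meant among the compounds shown, and "the series" means these compounds.

In a functional assay on A549 cells (Homo sapiens) for antiproliferative activity, read by MTT assay, with a stated time of 48 h (a higher number here means a weaker inhibitor, a lower number a stronger inhibitor), compound 1 `COc1ccc(-c2nc3cccc(-c4cc(OC)c(OC)c(OC)c4)c3o2)cc1` gives 2200 nM and compound 2 `COc1cc(-c2cccc3nc(-c4ccc(F)cc4)oc23)cc(OC)c1OC` gives 8700 nM, the higher of the two numbers. Compound 3 `COc1cc(-c2cccc3nc(-c4ccc(Cl)cc4)oc23)cc(OC)c1OC` differs from compound 2 by chloro in place of fluoro on an aromatic carbon, para to a large group: chloro in place of fluoro on an aromatic carbon. Within the data shown here, the one measured step bearing on this, a 4.0-fold higher number from compound 1 to compound 2 (0.60 log units; beyond the scatter), is fluoro in place of methoxy and is modest. Among the measured compounds shown here, no chloro compound has been measured, so only a modest shift towards a lower number is expected. The estimated change is a 1.6-fold lower number from compound 2 to compound 3 (0.20 log units; within the scatter). Compound 3 is estimated at 5500 nM, with a range of 2000 nM to 15000 nM.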

Compound 3, half-maximal inhibitory concentration: 5600 nM
Compound 3: the middle estimate sits 1.0-fold (0.01 log units) below what was measured; low and high end bracket the measured number.
By their numbers in this assay, from the lowest: compound 1; then compounds 3 and 2 (each within the scatter of the next).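

In this assay, a 1.6-fold lower number from compound 2 to compound 3 (0.19 log units; within the scatter) leaves chloro and fluoro at this position unseparated. Methoxy now stands apart from a second halogen, with a 2.5-fold higher number from compound 1 to compound 3 (0.41 log units; beyond the scatter), so compound 1 remains the strongest of the three. No measured evidence bears on the reason for these steps.

Still open, going by these compounds, is whether an amine, a hydroxyl or a longer alkoxy chain at this position would give a lower number than methoxy. On these data alone, whether these steps hold in other cell lines is also open.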